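The compounds below may be only part of what the source reports. "The series", "measured", "known", "first", "only" and "open" are said of these compounds alone.

Compound 1 `Cc1ccc(CN2C(=O)N(c3ccc(Cl)cc3)C(=O)C2CCC(=O)Nc2ccc(C(=O)NO)cc2)cc1`: in an assay on isolated protein for inhibition of protein deacetylase HDAC6 (Homo sapiens), read by fluorescence, with stated times of 5 min and 60 min (a lower number here means a stronger inhibitor, a higher number a weaker inhibitor), compound 1 gives 4.4 nM.
Compound 2 `Cc1ccc(CN2C(=O)N(c3ccc(Cl)cc3)C(=O)C2CCC(=O)Nc2cccc(C(=O)NO)c2)cc1`: in this assay compound 2 gives only a limit, > 40 nM.

Compound 2 thus stands at the limit of this assay, not at a number (the limit of > 40 nM in this assay, at which 1 of the 2 values shown sits). Compound 3 `Cc1ccc(CN2C(=O)N(c3ccc(Cl)cc3)C(=O)C2CCC(=O)NCc2ccc(C(=O)NO)cc2)cc1` differs from compound 2 by 4-(hydroxycarbamoyl)benzyl in place of 3-(hydroxycarbamoyl)phenyl on an amide-type nitrogen. For the measured compounds named here, the one measured step that bears on this is an at least 9.0-fold higher number from compound 1 to compound 2 (0.95 log units; beyond the scatter), a weakening beyond the scatter when the hydroxycarbamoyl group moved from the 4- to the 3-arrangement. Compound 3 carries it as compound 1 does, on a benzyl instead of a phenyl, so a fall in number beyond the scatter is expected, an at least 4.0-fold lower number from compound 2 to compound 3 (0.60 log units; beyond the scatter). Compound 3 is estimated at 10 nM, between 3 nM and 40 nM.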

Compound 3, half-maximal inhibitory concentration: 18.9 nM
For compound 3 the middle estimate is 1.9-fold (0.28 log units) below the measured one; low and high end bracket the measured number.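

Compound 2 remains a limit of the assay, not a number: the limit of > 40 nM in this assay, at which 1 of the 3 values shown sits. Even against that limit, 4-(hydroxycarbamoyl)benzyl in place of 3-(hydroxycarbamoyl)phenyl gives an at least 2.1-fold lower number from compound 2 to compound 3 (0.32 log units; beyond the scatter). The amide-type nitrogen is also sensitive to the change from phenyl to benzyl, with 4-(hydroxycarbamoyl)benzyl in place of 4-(hydroxycarbamoyl)phenyl giving a 4.3-fold higher number from compound 1 to compound 3 (0.63 log units; beyond the scatter).

Still open, from the compounds shown here alone, is how 3-(hydroxycarbamoyl)benzyl or a longer chain ending in hydroxycarbamoyl would read on this nitrogen. Going by these compounds, the full size of the step from compound 2 also remains unknown.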